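The source may report more compounds than this note shows. Statements on the series, on what has been measured and on what is new or still open speak of the compounds shown alone.

Measured in a functional assay on MCF-A cells (Homo sapiens) for cytotoxicity; a lower number here means a stronger inhibitor of growth, a higher number a weaker inhibitor of growth:
- compound 1 `COc1ccc(C2=C(c3ccc(SC)cc3)CC3CCCN3C2=O)cc1Br`: 6000 nM
- compound 2 `CSc1ccc(C2=C(c3ccc(F)c(C)c3)C(=O)N3CCCC3C2)cc1`: 500 nM
- compound 3 `COc1ccc(C2=C(c3ccc(SC)cc3)CC3CCCN3C2=O)cc1OC`: 600 nM

Compound 3, at 600 nM, sits within the scatter of compound 2 and well under compound 1. Compound 4 `COc1ccc(C2=C(c3ccc(SC)cc3)CC3CCCN3C2=O)cc1` carries hydrogen in place of methoxy on an aromatic carbon, ortho to a methoxy group: hydrogen in place of methoxy on an aromatic carbon. The closest evidence is a 10-fold lower number from compound 1 to compound 3 (1.00 log units; beyond the scatter), a change at the same carbon, beyond the scatter. The step of a 12-fold lower number from compound 1 to compound 2 (1.08 log units; beyond the scatter) replaces the whole aryl group and bears on it only loosely. Neither step shows what hydrogen does at this carbon, so no firm direction can be drawn. The expected step is a 1.2-fold higher number from compound 3 to compound 4 (0.07 log units; within the scatter), none beyond the scatter. For compound 4 the estimate is 700 nM, with an expected range of 150 nM to 3000 nM.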

Compound 4, concentration for 50% growth inhibition: 5000 nM
The estimate for compound 4 lay 7.1-fold (0.85 log units) below the measured number; the whole stated range lies below it.
By their numbers in this assay, from the lowest: compounds 2 and 3 (each within the scatter of the next); then compounds 4 and 1 (each within the scatter of the next).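

In this assay the second methoxy at this carbon, ortho to a methoxy group, proves to matter: hydrogen in its place costs a clear step (an 8.3-fold higher number from compound 3 to compound 4 (0.92 log units; beyond the scatter)), while hydrogen and bromo cannot be told apart (a 1.2-fold lower number from compound 1 to compound 4 (0.08 log units; within the scatter)). With hydrogen at this carbon, the 4-methoxyphenyl group also stands well apart from the 4-fluoro-3-methylphenyl group (a 10-fold higher number from compound 2 to compound 4 (1.00 log units; beyond the scatter)). Nothing available explains these steps.

On these data alone, what a hydroxyl, an amine or an ethoxy group would do at this carbon stays open. So does whether methoxy here is unique among groups or only one of several that give the lower number.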